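The compounds below may be only part of what the source reports. "The series", "measured", "known", "first", "only" and "open" are said of these compounds alone.

Among the compounds with values here, in a functional assay on MDA-MB-231 cells (Homo sapiens), read by microscopy and transwell migration, with a stated time of 24 h (on this read-out higher numbers stand for weaker inhibition and lower numbers for stronger inhibition), compound 1 `CCn1c(-c2ccc(C)cc2C)cs/c1=N\C(=O)c1ccccc1` gives 1950 nM and stands at the upper end of the numbers so far. Compound 3 `C#CCn1c(-c2ccc(C)cc2C)cs/c1=N\C(=O)c1ccccc1` gives 3890 nM and keeps level with it, as a 2.0-fold higher number from compound 1 to compound 3 (0.30 log units; within the scatter) stays within the scatter. Compound 2 `CCCCCCn1c(-c2ccc(C)cc2C)cs/c1=N\C(=O)c1ccccc1` gives 45 nM and stands well apart, with a 43-fold lower number from compound 1 to compound 2 (1.64 log units; beyond the scatter) as a large step and an 86-fold higher number from compound 2 to compound 3 (1.94 log units; beyond the scatter) as another.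

Compound 4 `CCn1c(-c2ccccc2)cs/c1=N\C(=O)c1ccccc1` carries phenyl in place of 2,4-dimethylphenyl on an aromatic carbon and keeps the ethyl group of compound 1. All three measured steps vary the chain on the aromatic nitrogen, and none varies the group on this aromatic carbon. Within the data shown here, they therefore show only that one change can be large or stay within the scatter. The step expected in this assay is a 1.5-fold higher number from compound 1 to compound 4 (0.19 log units; within the scatter) and is tentatively toward a higher number, probably not far beyond the scatter. For compound 4 the estimated value is 3000 nM with an expected range from 900 nM to 10000 nM on this thin basis.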

Compound 4, half-maximal inhibitory concentration: 51.5 nM
Compound 4: the middle estimate sits 58-fold (1.77 log units) above what was measured, and the stated range ends above it.
By their numbers in this assay, from the lowest: compounds 2 and 4 (each within the scatter of the next); then compounds 1 and 3 (each within the scatter of the next).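

In this assay, the aromatic carbon next to the ring nitrogen proves to be a sensitive place: a 38-fold lower number from compound 1 to compound 4 (1.58 log units; beyond the scatter), so the chain on the aromatic nitrogen is no longer the only place in the series where a single change moves the number beyond the scatter. The change removes the two methyl groups of 2,4-dimethylphenyl, going from 8 heavy atoms to 6 with the ethyl group kept, and the smaller group goes with the lower number in this single pair. No measurement at hand explains the size of this step.

As far as these compounds go, whether one methyl group or both must go stays open, as does the outcome of a chlorine or an amine on the phenyl. Also open, from the compounds shown here alone, is whether phenyl at this carbon combines with the longer chain of compound 2 to give a still lower number.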